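Phenylpropenoate-linked azetidinones: antiproliferative readout on epithelial cells

The source may hold more compounds than are shown below. What is called first, only, known or untested is meant among the compounds shown, and "the series" means these compounds.

Measured so far:
compound 1, `CCOC(=O)/C(=C/c1ccccc1)CN1C(=O)[C@@H](OC)[C@H]1c1ccc(Cl)cc1`, "not toxic" (no number reported)
compound 2, `CCOC(=O)/C(=C/c1ccccc1)CN1C(=O)[C@@H](OC)[C@H]1c1cccc([N+](=O)[O-])c1`, "not toxic" (no number reported)
compound 3, `COC(=O)/C(=C/c1ccccc1)CN1C(=O)[C@@H](OC)[C@H]1c1cccc(C(F)(F)F)c1`, 71800 nM

In an ADME assay on cells (Epithelial cell, Homo sapiens) for antiproliferative activity, read by MTT assay, with a stated time of 48 h (a lower number here means a stronger inhibitor, a higher number a weaker inhibitor), compound 1 gives "not toxic" (no number reported), with no number reported. Compound 2 likewise gives "not toxic" (no number reported) in this assay, again without a number. Among the measured compounds shown here, compound 3 is therefore the only member of the series with a numerical reading, 71800 nM, and it stands as a weak inhibitor on that number alone. Compound 4, `COC(=O)/C(=C/c1ccccc1)CN1C(=O)[C@@H](OC)[C@H]1c1ccccc1`, differs from compound 3 at one place: hydrogen in place of trifluoromethyl on an aromatic carbon. For the measured compounds named here, with no step between measured compounds to lean on, a step of the size of the usual scatter or smaller is expected, in either direction. Compound 4 is expected to give 90000 nM (range 35000 nM to 250000 nM), a step of a 1.3-fold higher number from compound 3 to compound 4 (0.10 log units; within the scatter) within the scatter.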

Compound 4, half-maximal inhibitory concentration: "not toxic" (no number reported)
For compound 4 the study gives words and no number; the estimate stays without a comparison.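

Compound 3 has a number and compound 4 only words, and no step can be read between them. The compounds shown leave open how far the 3-(trifluoromethyl)phenyl to phenyl change moves the reading. No evidence bears on this result.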